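Chloro in place of hydrogen on a sulfonamide-triazole series

This account rests on a few compounds, and the source may have more. Where it says the series, first, only, none or still open, it means among the compounds named here.

Measured compounds:
compound 1, `O=c1[nH]cc(S(=O)(=O)Nc2ccccc2-c2cn(-c3cccc(F)c3)nn2)c(=O)[nH]1`, 8130 nM
compound 2, `O=c1[nH]cc(S(=O)(=O)Nc2ccccc2-c2cn(-c3ccc(F)cc3)nn2)c(=O)[nH]1`, 6390 nM
compound 3, `O=c1[nH]cc(S(=O)(=O)Nc2ccc(-c3cn(-c4ccccc4)nn3)cc2)c(=O)[nH]1`, 7170 nM

All three were tested in a functional assay on A549 cells (Homo sapiens) for antiproliferative activity, read by MTT assay, with a stated time of 24 h; a lower number here means a stronger inhibitor, a higher number a weaker inhibitor. Compound 3, with the phenyl-triazole carried on the same ring as the sulfonamide nitrogen but at a different position, sits within the scatter of both compound 1 and compound 2; no order can be read among the three numbers. Within the data shown here, the one directly measured step, a 1.3-fold lower number from compound 1 to compound 2 (0.10 log units; within the scatter), is a shift of fluorine on the aromatic-nitrogen phenyl and was itself within the scatter.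

The next compound is compound 4, `O=c1[nH]cc(S(=O)(=O)Nc2ccc(-c3cn(-c4ccc(Cl)cc4)nn3)cc2)c(=O)[nH]1`. Relative to compound 3 the difference is chloro in place of hydrogen on an aromatic carbon. Among the measured compounds shown here, no measured step concerns a chloro substituent, and the only step available, a 1.3-fold lower number from compound 1 to compound 2 (0.10 log units; within the scatter), moves a different halogen on a different pattern of the shared core; it offers no direction. Only a small step is therefore expected in this assay, with no sign beyond the scatter. The estimate for compound 4 is 5500 nM, within 2500 nM to 12000 nM, which amounts to an expected step of a 1.3-fold lower number from compound 3 to compound 4 (0.12 log units; within the scatter).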

Compound 4, half-maximal inhibitory concentration: 1210 nM
Beside the measured number, compound 4's estimate is 4.5-fold (0.66 log units) above it; the whole stated range lies above it.
By their numbers in this assay, from the lowest: compound 4; then compounds 2, 3 and 1 (each within the scatter of the next).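

In this assay, among these compounds, the change from phenyl to 4-chlorophenyl gives a 5.9-fold lower number from compound 3 to compound 4 (0.77 log units; beyond the scatter) and is the first single-place change to lie beyond the scatter. Among the compounds shown here, the only earlier single-place step, a fluorine shift with a 1.3-fold lower number from compound 1 to compound 2 (0.10 log units; within the scatter) as its result, stayed within the scatter and gave no reading on substitution at this place. The new step shows that an aromatic carbon para to a large group responds in this assay to the entry of one chlorine atom, although the compounds shown offer no measurement that accounts for the size of the step.

The compounds shown leave open whether this step is particular to chloro or would also appear with a methyl group, a methoxy group, an amine or a carboxylic acid on the same aromatic carbon. They also leave open whether the same chloro change would give a step of similar size on the attachment pattern of compound 1 and compound 2, where the aryl group and the sulfonamide nitrogen are placed differently on their shared ring.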